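Adding a hydroxy(phenyl)methyl ester to the cyclohexyl anilide core

This account rests on a few compounds, and the source may have more. Where it says the series, first, only, none or still open, it means among the compounds named here.

Measured so far in an ADME assay on WI-38 cells (Homo sapiens) for inhibition, read by MTT assay, with a stated time of 72 h; on this read-out lower numbers stand for stronger inhibition and higher numbers for weaker inhibition:
- compound 1, `COc1ccc(C(=O)OC2(C(=O)Nc3ccc([N+](=O)[O-])cc3)CCCCC2)cc1`, gives 40 nM
- compound 2, `Cc1ccccc1C(=O)OC1(C(=O)Nc2ccc([N+](=O)[O-])cc2)CCCCC1`, gives 352 nM
- compound 3, `O=COC1(C(=O)Nc2ccc([N+](=O)[O-])cc2)CCCCC1`, gives 46.3 nM

All three share the same core and differ only in the group on the carbonyl carbon of the ester. On the numbers in hand, compound 3 sits second highest of the three, with compound 1 closest to it and compound 2 furthest away. The step of a 1.2-fold higher number from compound 1 to compound 3 (0.06 log units; within the scatter) lies within the scatter, while the step of a 7.6-fold lower number from compound 2 to compound 3 (0.88 log units; beyond the scatter) is a modest one beyond it.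

Compound 4, `O=C(OC1(C(=O)Nc2ccc([N+](=O)[O-])cc2)CCCCC1)C(O)c1ccccc1`, is not yet measured. It differs from compound 3 in one place: hydroxy(phenyl)methyl in place of hydrogen on a carbonyl carbon. The two measured steps that bear on this both concern replacing the hydrogen on that carbonyl carbon with a group carrying a six-membered aromatic ring; one of them left the number unchanged within the scatter, the other raised it modestly. A small rise in this assay is therefore the most likely outcome, though a result within the scatter of compound 3 cannot be excluded.

The estimate for compound 4 is 85 nM, within a range from 30 nM to 250 nM, which corresponds to an expected step of a 1.8-fold higher number from compound 3 to compound 4 (0.26 log units; within the scatter).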

Compound 4, half-maximal inhibitory concentration: 84.4 nM
Beside the measured number, compound 4's estimate is 1.0-fold (0.00 log units) above it; the measured number falls inside the stated range.
By their numbers in this assay, from the lowest: compounds 1, 3 and 4 (each within the scatter of the next, the first and the last beyond it); then compound 2.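

In this assay, placing hydroxy(phenyl)methyl on this carbonyl carbon in place of hydrogen gives a 1.8-fold higher number from compound 3 to compound 4 (0.26 log units; within the scatter) and so causes no readable change, which shows that this position accepts a group of 8 heavy atoms, including a hydroxy group, without a clear shift in the number. Compound 4 also shows that carrying a six-membered aromatic ring does not by itself fix the result, as the exchange of 2-methylphenyl gives a 4.2-fold lower number from compound 2 to compound 4 (0.62 log units; beyond the scatter) while the exchange of 4-methoxyphenyl gives a 2.1-fold higher number from compound 1 to compound 4 (0.32 log units; beyond the scatter) and these modest steps run in opposite directions. Nothing in the data shown explains why these groups differ.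

As far as these compounds go, the hydroxy group and the phenyl ring enter together in compound 4, so their separate contributions remain open, and a plain benzyl group or an amino(phenyl)methyl group on the same carbonyl carbon would help to tell them apart. Also open, from the compounds shown here alone, is how this position would respond to a group with no ring at all, such as a longer carbon chain or one ending in a carboxylic acid.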